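From cyano to amino on compound 2

The compounds below may be only part of what the source reports. "The series", "measured", "known", "first", "only" and "open" are said of these compounds alone.

In a functional assay on KB cells (nasopharynx, Homo sapiens) for antiproliferative activity (a higher number here means a weaker inhibitor, a lower number a stronger inhibitor), compound 1 `N#Cc1c[nH]c2c(NS(=O)(=O)c3ccc(N)cc3)cccc12` gives 4.4 ug/mL and compound 2 `N#Cc1ccc(S(=O)(=O)Nc2cccc3c(Cl)c[nH]c23)cc1` gives 11 ug/mL as the higher number of the two, which makes it the weaker inhibitor by a gap beyond the scatter. Compound 3 `Nc1ccc(S(=O)(=O)Nc2cccc3c(Cl)c[nH]c23)cc1` has amino in place of cyano on an aromatic carbon, para to a large group (amino in place of cyano on an aromatic carbon). Among the compounds with values here, no measured pair isolates this change. Compound 1 carries amino at that place and gives 4.4 ug/mL on a different core, so a moderate fall in the number is expected in this assay, an estimated 2.8-fold lower number from compound 2 to compound 3 (0.44 log units; beyond the scatter) in size. For compound 3 the expected value is 4 ug/mL within a range of 1 ug/mL to 12 ug/mL by this estimate.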

Compound 3, half-maximal inhibitory concentration: 10 ug/mL
Beside the measured number, compound 3's estimate is 2.5-fold (0.40 log units) below it; the measured number falls inside the stated range.
By their numbers in this assay, from the lowest: compound 1; then compounds 3 and 2 (each within the scatter of the next).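

In this assay amino in place of cyano on this aromatic carbon gives a 1.1-fold lower number from compound 2 to compound 3 (0.04 log units; within the scatter) with chloro held constant elsewhere, so this swap does not separate the two compounds. Chloro in place of cyano at the other changed place gives a 2.3-fold higher number from compound 1 to compound 3 (0.36 log units; beyond the scatter) with amino held constant, and this modest step is the one that exceeds the scatter. Nothing here explains either result.

From the compounds shown here alone, a methoxy group or a carboxylic acid in place of the amino remains open. So does whether amino and cyano would also match with cyano at the other place.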